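Trifluoromethyl on the pyridine ring of compound 1

A few compounds are considered here, and "the series" means these few. Any claim that something is new, unique, unknown or untested is made for them only; others in the source may bear on it.

Compound 1 `CN1CCC[C@H]1COc1cccnc1` is the reference of this small series. In an assay on membranes from brain for displacement of a labelled ligand from Neuronal acetylcholine receptor; alpha4/beta2 (Rattus norvegicus) (on this read-out higher numbers stand for weaker inhibition and lower numbers for stronger inhibition), compound 1 gives 0.15 nM, the lowest number of the three measured, with compound 2 nearest and compound 3 furthest. Compound 2 `Cc1ncccc1OC[C@@H]1CCCN1C` gives 22.9 nM in this assay, and compound 3 `CSc1ncccc1OC[C@@H]1CCCN1C` gives 559 nM. The measured steps are a 150-fold higher number from compound 1 to compound 2 (2.18 log units; beyond the scatter) and a 3700-fold higher number from compound 1 to compound 3 (3.57 log units; beyond the scatter); between the two substituted compounds the step is a 24-fold higher number from compound 2 to compound 3 (1.39 log units; beyond the scatter).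

Compound 4 `CN1CCC[C@H]1COc1cncc(C(F)(F)F)c1` differs from compound 1 by trifluoromethyl in place of hydrogen on an aromatic carbon. Both measured steps from compound 1 replace an aromatic hydrogen with a small group and each lowers binding strongly, so the expectation for compound 4 is a weaker binding than compound 1, beyond the scatter, though the measured steps give no direct reading for a trifluoromethyl at the place occupied here. For compound 4 the estimated step is a 10-fold higher number from compound 1 to compound 4 (1.00 log units; beyond the scatter). The estimate for compound 4 in this assay is 1.5 nM, expected to fall between 0.3 nM and 8 nM.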

Compound 4, inhibition constant: 1.83 nM
Estimate against measurement, compound 4: 1.2-fold (0.09 log units) below; the measured number falls inside the stated range.
By their numbers in this assay, from the lowest: compound 1; then compound 4; then compound 2; then compound 3.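

At this place, on an aromatic carbon two atoms from the ring nitrogen, trifluoromethyl in place of hydrogen gives a 12-fold higher number from compound 1 to compound 4 (1.09 log units; beyond the scatter) in this assay, so this change costs binding beyond the scatter, though compound 4 still ranks second of the four compounds. This step is smaller than the two earlier steps from compound 1, but those steps involve other groups, so group and place cannot be separated. No available evidence explains the size of this step.

Open, from the compounds shown here alone, is how a methyl group, a chlorine atom or an amine at this same place would read, which would show whether the step follows trifluoromethyl itself or any replacement of hydrogen here. Also open, going by these compounds, is how trifluoromethyl would read at the place that carries methyl in compound 2.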